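Methoxy for Hydroxymethyl on Two Cores, Same Cell Assay

The source may report more compounds than this note shows. Statements on the series, on what has been measured and on what is new or still open speak of the compounds shown alone.

Measured compounds:
compound 1 `O=c1c2cc([N+](=O)[O-])ccc2n(CCCO)n1Cc1ccccc1` gives in an ADME assay on L929 cells (Mus musculus) for cytotoxicity, read by resazurin assay, with a stated time of 48 h (a lower number here means that less compound is tolerated, a higher number that more compound is tolerated), the value > 256000 nM, which is a limit of the assay and not a number.
compound 2 `COCCn1c2ccc([N+](=O)[O-])cc2c(=O)n1Cc1ccccc1` gives in this assay the value > 256000 nM, again a limit.
compound 3 `O=[N+]([O-])c1ccc2nn(Cc3ccccc3)c(OCCCO)c2c1` gives in this assay the value > 256000 nM, also a limit.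

The change methoxy in place of hydroxymethyl on a saturated chain carbon, two bonds along the chain from an aromatic nitrogen gives the step that the two limits leave unreadable from compound 1 to compound 2. How the core of compound 3 differs from that of compound 1 is not broken down here. Compound 4 `COCCOc1c2cc([N+](=O)[O-])ccc2nn1Cc1ccccc1` carries the same kind of change, (methoxy in place of hydroxymethyl on a saturated chain carbon, two bonds along the chain from an oxygen on an aromatic ring), though here the place is two bonds from an oxygen on an aromatic ring rather than from an aromatic nitrogen. Because (the limit of > 256000 nM in this assay, at which 3 of the 3 values shown sit), the step from compound 3 to compound 4 is expected to be a step that the limit leaves unreadable from compound 3 to compound 4, again most likely unreadable. Compound 4 is therefore estimated at 400000 nM in this assay.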

Compound 4, concentration lethal to 50% of the cells: > 256000 nM
Compound 4 was reported as a limit (the forecaster's own chance of this, stated with the estimate: 85%); the middle value lies beyond the limit too.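

No step can be read between compound 3 and compound 4, because both values are limits of the assay and not numbers: the limit of > 256000 nM in this assay, at which 4 of the 4 values shown sit.
Going by these compounds, whether methoxy in place of hydroxymethyl changes how much compound the cells tolerate stays open on both cores.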